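Shortening the amide substituent from hexyl to cyclopentyl

The compounds below may be only part of what the source reports. "The series", "measured", "known", "first", "only" and "open" are said of these compounds alone.

Measured compounds:
- Compound 1, `CCNC(=O)CC1CCc2cc(OC)c(OC)cc21`: 26%
- Compound 2, `CCCCNC(=O)CC1CCc2cc(OC)c(OC)cc21`: 24%
- Compound 3, `CCCCCCNC(=O)CC1CCc2cc(OC)c(OC)cc21`: 41.5%

All three share one core and differ only in the group on the amide nitrogen. They were tested in a functional assay on the whole organism (strain Wistar) for inhibition, with Rattus norvegicus as the target, read by paw edema, with stated times of 60 min and 2 h, at a dose of 100 mg/kg by the oral route; on this read-out lower numbers stand for less inhibition and higher numbers for more inhibition at the one dose given (going by the name of the read-out). Compound 3 gives the highest number of the three. Compound 1 and compound 2 are within the scatter of each other, as a number 2 percentage points lower from compound 1 to compound 2 (within the scatter) shows, so no order can be read between them. Lengthening the chain to hexyl is the only change that moved the read-out beyond the scatter: a number 15.5 percentage points higher from compound 1 to compound 3 (beyond the scatter) and a number 17.5 percentage points higher from compound 2 to compound 3 (beyond the scatter).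

Compound 4, `COc1cc2c(cc1OC)C(CC(=O)NC1CCCC1)CC2`, has not yet been measured. It differs from compound 3 in one place: cyclopentyl in place of hexyl on an amide-type nitrogen. Among the measured compounds shown here, no measured pair matches this change, since every measured compound carries an open chain. The two steps that bear on it are those leading to compound 3, both of modest size and both in the same direction, and compound 4 carries fewer carbons than compound 3 and more than compound 2. A step downward from compound 3 is therefore expected, estimated as a number 9.5 percentage points lower from compound 3 to compound 4 (within the scatter), though a result within the scatter would not surprise. For compound 4 the expected value is 32%, with a range from 18% to 46%.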

Compound 4, a percentage reported as inhibition, in the whole organism at one dose (the size of the read-out at that dose, not a potency): 52%
Compound 4: the middle estimate sits 20 percentage points below what was measured, outside the stated range (above it).
By their numbers in this assay, from the lowest: compounds 2 and 1 (each within the scatter of the next); then compound 3; then compound 4.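

In this assay the cyclopentyl ring on the amide nitrogen gives the highest number of the series, with a number 10.5 percentage points higher from compound 3 to compound 4 (beyond the scatter) against hexyl, a number 28 percentage points higher from compound 2 to compound 4 (beyond the scatter) against butyl, and a number 26 percentage points higher from compound 1 to compound 4 (beyond the scatter) against ethyl as the three steps. Until now only the open chains had been seen here, and hexyl alone stood apart from the others, so a longer chain could have seemed the way to a higher number; compound 4 goes against that reading, since its cyclopentyl has 5 heavy atoms to the 6 of hexyl, and compounds 1 and 2 go against it as well, being within the scatter of each other. This position on the amide nitrogen therefore accepts a closed ring as well as an open chain, and the count of carbons alone does not set the order, while nothing among the data available explains why the ring gives more than the chains.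

As far as these compounds go, whether this gain belongs to rings in general or to this ring size stays open, and cyclobutyl and cyclohexyl on the same nitrogen would test that directly. A branched chain such as isopentyl would show whether closing the ring is needed at all, or whether a more compact carbon group is enough.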